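Trimming the Amide Substituent of Compound 1

The compounds below may be only part of what the source reports. "The series", "measured", "known", "first", "only" and "open" are said of these compounds alone.

Compound 1 `CCN(CC)S(=O)(=O)c1ccc(S(=O)(=O)N2CCC[C@@H](C(=O)NC3CN(C(=O)OC(C)(C)C)C3)C2)cc1` is one of three compounds tested in a functional assay on BXPC-3 cells (Homo sapiens) for inhibition, read by MTT assay, with a stated time of 7 days; a lower number here means a stronger inhibitor, a higher number a weaker inhibitor. In this assay compound 1 gives 1800 nM, the second highest of the three numbers. Compound 2 `CCOC(=O)[C@@H]1CCCN(S(=O)(=O)c2ccc(S(=O)(=O)N(CC)CC)cn2)C1` gives 1400 nM in this assay, a number that lies within the usual scatter of the value of compound 1. Compound 3 `CC(C)c1noc(N2CCN(C(=O)[C@@H]3CCCN(S(=O)(=O)c4ccc(S(=O)(=O)NC5CC5)cc4)C3)CC2)n1` gives 6700 nM in this assay, a higher number than that of compound 1 and beyond the scatter. Compound 4 `CCN(CC)S(=O)(=O)c1ccc(S(=O)(=O)N2CCC[C@@H](C(=O)NC)C2)cc1` has not yet been measured. It differs from compound 1 in one place: methyl in place of 1-(tert-butoxycarbonyl)azetidin-3-yl on an amide-type nitrogen. Put another way, methylamino stands where (1-(tert-butoxycarbonyl)azetidin-3-yl)amino stood. Among the measured compounds shown here, no pair of measured compounds shows this change, so the expected size of the step rests on the structural change alone. A modest step toward a higher number is expected, a 1.7-fold higher number from compound 1 to compound 4 (0.22 log units; within the scatter), perhaps still within the scatter. Compound 4 is estimated at 3000 nM in this assay, with a range from 1000 nM to 9000 nM.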

Compound 4, half-maximal inhibitory concentration: 13800 nM
Beside the measured number, compound 4's estimate is 4.6-fold (0.66 log units) below it, outside the stated range (above it).
By their numbers in this assay, from the lowest: compounds 2 and 1 (each within the scatter of the next); then compound 3; then compound 4.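

Replacing 1-(tert-butoxycarbonyl)azetidin-3-yl with methyl on the amide-type nitrogen gives, in this assay, a 7.7-fold higher number from compound 1 to compound 4 (0.88 log units; beyond the scatter). This shows that the group at this position strongly affects the number, and that methyl does not hold the level reached with the larger group. Compounds 2 and 3 differ from compound 1 in more than one place, so neither could show this. Nothing shown here explains the size of this step.

Going by these compounds, it remains open whether the difference lies with the tert-butoxycarbonyl group, with the azetidine ring, or simply with the size of the substituent. A free azetidin-3-yl, a longer chain such as butyl, or a benzyl group on the same nitrogen would help to separate these possibilities.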